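Thiourea series: a trifluoromethyl on the anilino ring

This account rests on a few compounds, and the source may have more. Where it says the series, first, only, none or still open, it means among the compounds named here.

The shared core of these compounds carries a substituent on an amine nitrogen in a ring. Compound 1 `Cc1ccccc1CN1CCc2c(sc(NC(=O)c3ccccc3Cl)c2C(N)=O)C1` bears a 2-methylphenyl on a saturated chain carbon there; in a functional assay on HL-60 cells (Homo sapiens) for antiproliferative activity, with a stated time of 24 h (a higher number here means a weaker inhibitor, a lower number a stronger inhibitor), compound 1 gives only a limit, > 50000 nM. Compound 2 `NC(=O)c1c(NC(=O)c2ccccc2Cl)sc2c1CCN(Cc1ccc(Cl)cc1Cl)C2`, with 2,4-dichlorophenyl in place of 2-methylphenyl, gives 8010 nM, a step of an at least 6.2-fold lower number from compound 1 to compound 2 (0.79 log units; beyond the scatter). Compound 3 `NC(=O)c1c(NC(=O)c2ccccc2Cl)sc2c1CCN(C(=S)Nc1ccccc1)C2` gives 5940 nM, a step of an at least 8.4-fold lower number from compound 1 to compound 3 (0.92 log units; beyond the scatter), while the step of a 1.3-fold lower number from compound 2 to compound 3 (0.13 log units; within the scatter) separates it from compound 2. Compound 3 thus holds the lowest of the two numbers shown, with compound 2 within the scatter of it and compound 1 known only as a limit.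

Compound 4 `NC(=O)c1c(NC(=O)c2ccccc2Cl)sc2c1CCN(C(=S)Nc1ccc(C(F)(F)F)cc1)C2` differs from compound 3 by trifluoromethyl in place of hydrogen on an aromatic carbon. No measured step alters a substituent on that ring: the three steps shown all exchange the whole group on the amine nitrogen, and the one step among numbers, from compound 2 to compound 3, stayed within the scatter. The step of a 1.2-fold lower number from compound 3 to compound 4 (0.07 log units; within the scatter) is therefore expected to be small, with no clear direction beyond the scatter. Compound 4 is estimated at 5000 nM, within 1500 nM to 16000 nM.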

Compound 4, half-maximal inhibitory concentration: 7590 nM
For compound 4 the middle estimate is 1.5-fold (0.18 log units) below the measured one, within the range that was stated.
By their numbers in this assay, from the lowest: compounds 3, 4 and 2 (each within the scatter of the next). At a limit, above all of these: compound 1.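

For the compounds shown here, compound 4 gives the first reading of a change on the anilino ring itself, since the earlier steps all exchanged the whole group on the amine nitrogen. In this assay, trifluoromethyl in place of hydrogen, on an aromatic carbon para to a large group, produces a 1.3-fold higher number from compound 3 to compound 4 (0.11 log units; within the scatter), so this position takes a trifluoromethyl without the number moving beyond the scatter of repeated measurements. Nothing among the data shown accounts for the size of this step, and with a single substituent at this position, the result marks one point of tolerance on the ring and does not establish a trend.

The compounds shown leave open whether a methoxy, an amine or a carboxylic acid in the same place would also stay within the scatter of compound 3, or would move the number clearly in either direction. They also leave open whether a second substituent on this ring, such as a chlorine, would change the number any more than trifluoromethyl does alone.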